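The compounds below may be only part of what the source reports. "The series", "measured", "known", "first", "only" and "open" are said of these compounds alone.

Compound 1 `Nc1sc(-c2ccc(Cl)cc2)c(-c2ccc(Cl)cc2)c1C(=O)N1CCCCC1`: 4620 nM
Compound 2 `CC1CN(C(=O)c2c(N)sc(-c3ccc(Cl)cc3)c2-c2ccc(Cl)cc2)CCN1`: 4930 nM

In a functional assay on A549 cells (Homo sapiens) for inhibition, read by sulforhodamine B assay, with a stated time of 72 h (on this read-out lower numbers stand for stronger inhibition and higher numbers for weaker inhibition), compound 1 gives 4620 nM and compound 2 gives 4930 nM; the two stand together, neither set apart from the other within the scatter. Compound 3 `Nc1sc(-c2ccc(Cl)cc2)c(-c2ccc(Cl)cc2)c1C(=O)NC1CCC(O)CC1` is not yet measured. It differs from compound 1 in one place: (4-hydroxycyclohexyl)amino in place of piperidin-1-yl on a carbonyl carbon. Within the data shown here, the only measured step that bears on this is a change at the same carbonyl carbon, a 1.1-fold higher number from compound 1 to compound 2 (0.03 log units; within the scatter), which stayed within the scatter. On that basis the expected step is a 1.1-fold higher number from compound 1 to compound 3 (0.03 log units; within the scatter), nothing beyond the scatter. Compound 3 is therefore estimated at 5000 nM, within a range of 2000 nM to 13000 nM.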

Compound 3, half-maximal inhibitory concentration: 250 nM
For compound 3 the middle estimate is 20-fold (1.30 log units) above the measured one; measured number below the stated range.
By their numbers in this assay, from the lowest: compound 3; then compounds 1 and 2 (each within the scatter of the next).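

The group on this carbonyl carbon can matter a great deal, even though the earlier swap stayed within the scatter: (4-hydroxycyclohexyl)amino in place of piperidin-1-yl gives an 18-fold lower number from compound 1 to compound 3 (1.27 log units; beyond the scatter) and in place of 3-methylpiperazin-1-yl gives a 20-fold lower number from compound 2 to compound 3 (1.29 log units; beyond the scatter) in this series. The entering group differs in several ways at once, with a ring of carbon only, a hydroxyl and an amide hydrogen. Nothing available explains the stronger inhibition. As far as these compounds go, the role of the hydroxyl stays open, and plain cyclohexylamino or 4-aminocyclohexylamino would help separate it from the ring and the amide hydrogen.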